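Buffer half-life: phenyl to pyridin-4-yl at the chain end

The source may report more compounds than this note shows. Statements on the series, on what has been measured and on what is new or still open speak of the compounds shown alone.

Measured compounds and half-lives:
compound 1 `Cn1cc([C@@H](O)[C@H]2C(=O)N3C(C(=O)O)=C(C(C)(C)C)O[C@H]23)nn1` — 6.8 h
compound 2 `CC(C)(C)C1=C(C(=O)O)N2C(=O)[C@H]([C@H](O)c3ccncc3)[C@H]2O1` — 6.4 h
compound 3 `CC(C)(C)C1=C(C(=O)O)N2C(=O)[C@H]([C@H](O)CCc3ccccc3)[C@H]2O1` — 21 h

In an ADME assay, in phosphate buffer, at 28 degrees C, at pH 7.0 (on this read-out higher numbers stand for a longer-lived compound and lower numbers for a shorter-lived compound), compound 3 holds the highest of the three numbers, reached through a 3.1-fold higher number from compound 1 to compound 3 (0.49 log units; beyond the scatter) and a 3.3-fold higher number from compound 2 to compound 3 (0.52 log units; beyond the scatter). Compound 4 `CC(C)(C)C1=C(C(=O)O)N2C(=O)[C@H]([C@H](O)CCc3ccncc3)[C@H]2O1` differs from compound 3 by pyridin-4-yl in place of phenyl on a saturated chain carbon, three bonds along the chain from an oxygen on a saturated carbon and a saturated ring carbon. Among the measured compounds shown here, no measured step exchanges phenyl for pyridin-4-yl at this place. The nearest guidance is a 1.1-fold lower number from compound 1 to compound 2 (0.03 log units; within the scatter), where pyridin-4-yl entered on the carbinol carbon without a shift beyond the scatter, while a 3.3-fold higher number from compound 2 to compound 3 (0.52 log units; beyond the scatter) moved the aryl group out along a chain and raised the number modestly. Since the chain stays in compound 4, only a small step is expected, a 1.5-fold lower number from compound 3 to compound 4 (0.18 log units; within the scatter), and compound 4 is estimated at 14 h, between 6 h and 30 h.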

Compound 4, half-life: 13.7 h
Compound 4: middle estimate off by 1.0-fold (0.01 log units), on the high side; the measured number falls inside the stated range.
By their numbers in this assay, from the lowest: compounds 2, 1, 4 and 3 (each within the scatter of the next, the first and the last beyond it).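

In this assay, a 1.5-fold lower number from compound 3 to compound 4 (0.19 log units; within the scatter) shows that pyridin-4-yl and phenyl are not separated at this place on the chain. With pyridin-4-yl on both sides, the chain alone now gives a 2.1-fold higher number from compound 2 to compound 4 (0.33 log units; beyond the scatter) as a modest step, while a 2.0-fold higher number from compound 1 to compound 4 (0.30 log units; within the scatter) stays within the scatter against the 1-methyl-1H-1,2,3-triazol-4-yl compound. No supporting data are available to explain these steps.

Still open, going by these compounds, is whether a longer chain keeps the half-life of compound 4 at 13.7 h. An amine or a carboxylic acid in place of pyridin-4-yl at this place also remains untested in the compounds shown.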